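Benzofuran in Place of Methoxyphenyl on the Sulfonyl Sulfur

The source may hold more compounds than are shown below. What is called first, only, known or untested is meant among the compounds shown, and "the series" means these compounds.

The series shares one core, seen in compound 1 `CCN(Cc1ccccc1)C(=O)C1CCN(S(=O)(=O)c2ccc(OC)cc2)CC1`, which carries a 4-methoxyphenyl on its sulfonyl sulfur. In a functional assay on CHO cells for positive allosteric modulation of muscarinic acetylcholine receptor M5 (Homo sapiens), read by calcium flux (on this read-out higher numbers stand for larger maximal responses and lower numbers for smaller maximal responses), compound 1 gives 84%. Two close relatives were also prepared: compound 2 `CCN(Cc1ccccc1)C(=O)C1CCN(S(=O)(=O)c2ccccc2OC)CC1`, in which the methoxy sits elsewhere on the phenyl, and compound 3 `CCN(Cc1ccccc1)C(=O)C1CCN(S(=O)(=O)c2ccncc2)CC1`, which carries a pyridine in that position. In this assay, among the measured compounds shown here, compound 2 gives "not determined" (no result reported) and compound 3 gives "not determined" (no result reported), so compound 1 stands alone with the only number in hand, and no step between two measured compounds can be drawn.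

Compound 4 `CCN(Cc1ccccc1)C(=O)C1CCN(S(=O)(=O)c2ccc3occc3c2)CC1` differs from compound 1 in one place: 1-benzofuran-5-yl in place of 4-methoxyphenyl on a sulfonyl sulfur. The ring that leaves and the ring that enters each hold a single hydrogen-bond acceptor and no donor, and the new group adds one fused five-membered ring with one hetero atom.

For the measured compounds named here, with no measured step to lean on, the author expects the step of a number 4 percentage points lower from compound 1 to compound 4 (within the scatter) to stay within the scatter of repeated measurements, since compound 1 gives 84% and nothing yet points either way. For compound 4 the maximal response in this assay is estimated at 80%, within a range from 58% to 100%.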

Compound 4, largest response reached (reported as percent of maximum), in percent of the reference or control that the assay uses: 80%
Beside the measured number, compound 4's estimate shows no gap at the digits printed, and the stated range covers the measured number.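

In this assay, among the compounds shown here, the exchange of 4-methoxyphenyl for 1-benzofuran-5-yl on a sulfonyl sulfur gives a number 4 percentage points lower from compound 1 to compound 4 (within the scatter), and this is the first measured step at this position, since the steps to compound 2 and compound 3 cannot be read. It shows that the maximal response of compound 1 is kept within the usual scatter when the single aromatic ring of carbon gives way to a group carrying a further five-membered aromatic ring with one hetero atom, so this position tolerates that added ring in this one pair. No measurement at hand bears on why the two groups read alike.

Still open, as far as these compounds go, is whether the response would hold with a group of another kind on the sulfonyl sulfur, such as a plain methyl, a cyclohexyl or a phenyl carrying a carboxylic acid, or with the other benzofuran attachment points. The compounds shown also leave open how the rest of the shared core contributes, for instance with a cyclopropyl group in place of the ethyl.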